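The source may report more compounds than this note shows. Statements on the series, on what has been measured and on what is new or still open speak of the compounds shown alone.

Three measured compounds share one core and differ only in the group attached to a saturated ring carbon. Compound 1 `Cc1nn(-c2ncnc3nc[nH]c23)c2c1C(OCc1ccccc1F)CC(=O)N2` gives 4 nM in a functional assay on HEK293 cells for agonist activity at G-protein coupled receptor 39 (Homo sapiens), read by scintillation proximity assay and inositol phosphate accumulation, with a stated time of 75 min, in the presence of a further agent that is not named here; on this read-out higher numbers stand for an effect only at larger amounts of compound and lower numbers for an effect already at smaller amounts. Compound 2 `Cc1nn(-c2ncnc3nc[nH]c23)c2c1C(OCc1ccccc1C#N)CC(=O)N2` gives 8 nM in this assay, with the step of a 2.0-fold higher number from compound 1 to compound 2 (0.30 log units; within the scatter) between them. Compound 3 `Cc1nn(-c2ncnc3nc[nH]c23)c2c1C(C(=O)NCc1ccccc1)CC(=O)N2` gives 5 nM in this assay. Compound 3 stands second highest of these three numbers, yet its steps to the others, a 1.3-fold higher number from compound 1 to compound 3 (0.10 log units; within the scatter) and a 1.6-fold lower number from compound 2 to compound 3 (0.20 log units; within the scatter), both fall within the scatter, so the three compounds cannot be told apart on these numbers.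

Compound 4 `Cc1nn(-c2ncnc3nc[nH]c23)c2c1C(OCCn1nccc1C)CC(=O)N2` has not been measured. The change from compound 3 is a group of 9 heavy atoms (6 carbon, 2 nitrogen, 1 oxygen; one five-membered aromatic ring with 2 hetero atoms) in place of a group of 10 heavy atoms (8 carbon, 1 nitrogen, 1 oxygen; one six-membered aromatic ring of carbon only), on a saturated ring carbon. The measured steps all exchange groups that each keep one six-membered aromatic ring of carbon only, and none of them moved the number beyond the scatter. For the measured compounds named here, no measured step removes that ring or introduces a five-membered aromatic ring with two hetero atoms on a chain, so the present change is not directly covered. A moderate rise in the number is expected, a 3.0-fold higher number from compound 3 to compound 4 (0.48 log units; beyond the scatter), with wide uncertainty. Compound 4 is therefore expected to give 15 nM in this assay, with a range from 4 nM to 60 nM.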

Compound 4, half-maximal effective concentration: 10 nM
Estimate against measurement, compound 4: 1.5-fold (0.18 log units) above, within the range that was stated.
By their numbers in this assay, from the lowest: compounds 1, 3, 2 and 4 (each within the scatter of the next, the first and the last beyond it).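

In this assay, this saturated ring carbon tolerates a group without the six-membered aromatic ring of carbon only: with a 2.0-fold higher number from compound 3 to compound 4 (0.30 log units; within the scatter) and a 1.3-fold higher number from compound 2 to compound 4 (0.10 log units; within the scatter), compound 4 cannot be told apart from either neighbour, even though its group has 0 hydrogen-bond donors where benzylcarbamoyl has 1, so the amide hydrogen is not needed to stay in this range. For the compounds shown here, the first change at this position to pass the scatter is a 2.5-fold higher number from compound 1 to compound 4 (0.40 log units; beyond the scatter), a modest step, and since compound 2 lies within the scatter of both compounds, this is a small gap at the ends of the series rather than a clear ranking of the four. Nothing at hand explains this gap.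

The compounds shown do not tell whether the methyl on the pyrazole or the length of the chain carrying it matters, since only (5-methyl-1H-pyrazol-1-yl)methyl appears here and no unsubstituted pyrazole or longer chain is among them. They also leave open how this position responds to a group of a different kind, such as a carboxylic acid or an amine like piperidine, in place of these neutral groups.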